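A few compounds are considered here, and "the series" means these few. Any claim that something is new, unique, unknown or untested is made for them only; others in the source may bear on it.

Compound 2 `Cc1cc(=O)n(-c2ccccc2C(F)(F)F)nc1C(=O)Nc1ccc(Oc2ncnc3ccsc23)c(F)c1` gives 6020 nM in a functional assay on MCF7 cells (Homo sapiens) for cytotoxicity, read by MTT assay, with a stated time of 72 h; on this read-out lower numbers stand for stronger inhibition and higher numbers for weaker inhibition. Compound 1 `Cc1cc(=O)n(-c2ccc(Br)cc2F)nc1C(=O)Nc1ccc(Oc2ncnc3ccsc23)cc1` gives 9360 nM in this assay, and the gap between these two numbers lies within the usual scatter of repeated measurements, so the two compounds cannot be told apart on this read-out. Compound 3 `Cc1cc(=O)n(-c2ccc(Br)cc2F)nc1C(=O)Nc1ccc(Oc2ncnc3ccsc23)c(F)c1` has not yet been measured. It differs from compound 2 in one place: 4-bromo-2-fluorophenyl in place of 2-(trifluoromethyl)phenyl on an aromatic nitrogen. Going by the values given here, the group that enters is the one that compound 1 already carries, while the rest of compound 3 matches compound 2. Among the compounds with values here, compound 1 and compound 2 differ in two places at once, so no step between measured compounds isolates this single exchange. The step of a 1.2-fold higher number from compound 2 to compound 3 (0.10 log units; within the scatter) is expected to be small, with no movement beyond the scatter in either direction. Compound 3 is estimated at 7500 nM in this assay, with a range from 3000 nM to 19000 nM.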

Compound 3, half-maximal inhibitory concentration: 1550 nM
For compound 3 the middle estimate is 4.8-fold (0.68 log units) above the measured one; measured number outside the range, below it.
By their numbers in this assay, from the lowest: compound 3; then compounds 2 and 1 (each within the scatter of the next).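

In this assay the exchange on the aromatic nitrogen is not neutral: 4-bromo-2-fluorophenyl in place of 2-(trifluoromethyl)phenyl gives a 3.9-fold lower number from compound 2 to compound 3 (0.59 log units; beyond the scatter). The fluoro in place of hydrogen on an aromatic carbon, which the earlier pair could not isolate, also moves the number, with a 6.0-fold lower number from compound 1 to compound 3 (0.78 log units; beyond the scatter), so each of the two differences between compound 1 and compound 2 registers when taken alone, although those two compounds cannot be told apart. Nothing at hand explains either step.

On these data alone, it remains open whether the fluoro step would hold with 2-(trifluoromethyl)phenyl on the nitrogen, and whether the bromine or the fluorine of the entering group carries its step. As far as these compounds go, how an amine or a carboxylic acid on that phenyl ring would read is also open.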